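Replacing isopropyl with 4-methylphenyl on a sulfonyl sulfur

This account rests on a few compounds, and the source may have more. Where it says the series, first, only, none or still open, it means among the compounds named here.

Compound 1 (`COc1ccc(-c2c(C)nc3c(N4CC[C@@H](NC(=O)Nc5ccccc5)C4)cc(C)nn23)cc1OC`) and compound 2 (`COc1ccc(-c2c(C)nc3c(N4CC[C@@H](NS(=O)(=O)C(C)C)C4)cc(C)nn23)cc1OC`) have the shared core and differ in the group on an amine nitrogen. In an ADME assay on microsomes from liver (Mus musculus) for metabolic stability, read by LC-MS, with NADPH named in the record, with a stated time of 60 min, tested at 1 uM, in the absence of a further agent (a higher number here means that more of the compound is left, a lower number that less of the compound is left), compound 1 gives > 95%, which is a limit and not a number. Compound 2 gives > 95%, which is also a limit. What the two measurements show is the limit of > 95% in this assay, at which 2 of the 2 values shown sit. Within the data shown here, the only measured step, with isopropylsulfonyl in place of phenylcarbamoyl, is a step that the two limits leave unreadable from compound 1 to compound 2, so it offers no size to carry forward.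

Compound 3 (`COc1ccc(-c2c(C)nc3c(N4CC[C@@H](NS(=O)(=O)c5ccc(C)cc5)C4)cc(C)nn23)cc1OC`) keeps the core and the sulfonamide of compound 2 but has 4-methylphenyl in place of isopropyl on a sulfonyl sulfur. This new group has not yet been measured on this core, so the expectation rests only on the two limits. The likeliest outcome in this assay is no step beyond the scatter, and any readable step is expected to run downward. The estimated step is a number at least 5 percentage points lower from compound 2 to compound 3 (that floor lies within the scatter). In this assay the estimate for compound 3 is 90%, expected to lie between 68% and 100%.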

Compound 3, percent of the compound remaining: > 95%
Compound 3 was reported as a limit (the forecaster's own chance of this, stated with the estimate: 45%); at least 5 percentage points between middle value and limit.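

No step from compound 1 or compound 2 to compound 3 can be read in this assay, because all three compounds stand at one limit and not at numbers: the limit of > 95% in this assay, at which 3 of the 3 values shown sit.

The compounds shown leave open how much of each compound remains past that limit, and whether 4-methylphenyl and isopropyl on a sulfonyl sulfur differ at all in this assay.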